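The source may hold more compounds than are shown below. What is called first, only, known or untested is meant among the compounds shown, and "the series" means these compounds.

Working notes on the series. In an ADME assay on microsomes from liver (Mus musculus) for metabolic stability, read by LC-MS, with a stated time of 1 h, tested at 5 uM (a lower number here means that less of the compound is left, a higher number that more of the compound is left), compound 1 `Cc1nc(-c2ccccc2)c(C(=O)N2CCN(c3cccc(C)c3C)CC2)o1` gives 83.6%, the highest of the three numbers; compound 2 `Cc1nc(-c2cccc(F)c2)c(C(=O)N2CCN(c3cc(Cl)cc(Cl)c3)CC2)o1` gives 40.7% and compound 3 `Cc1nc(-c2ccc(F)cc2)c(C(=O)N2CCN(c3cc(Cl)cc(Cl)c3)CC2)o1` gives 31.1%, both well beyond the scatter below it. Going by the values given here, the one measured step, a number 9.6 percentage points lower from compound 2 to compound 3 (within the scatter), concerns the other aryl group and stays within the scatter. Compound 4 `COc1cc(OC)cc(N2CCN(C(=O)c3oc(C)nc3-c3ccccc3)CC2)c1` differs from compound 1 by 3,5-dimethoxyphenyl in place of 2,3-dimethylphenyl on an amine nitrogen in a ring. Among the compounds with values here, no measured pair changes this group, so no step bears directly on it; the only guide is the spread of the three values. The estimate for compound 4 is therefore set below compound 1 with a wide range, at 55% (from 25% to 85%), a step of a number 28.6 percentage points lower from compound 1 to compound 4 (beyond the scatter) expected, direction downward but uncertain.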

Compound 4, percent of the compound remaining: 0.7%
Beside the measured number, compound 4's estimate is 54.3 percentage points above it; measured number outside the range, below it.
By their numbers in this assay, from the lowest: compound 4; then compounds 3 and 2 (each within the scatter of the next); then compound 1.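

In this assay the change of 3,5-dimethoxyphenyl in place of 2,3-dimethylphenyl on an amine nitrogen in a ring gives a number 82.9 percentage points lower from compound 1 to compound 4 (beyond the scatter) and is a large step. Going by these compounds alone, the only earlier step concerned the other aryl group and stayed within the scatter, so this is the first sign that the group on this nitrogen can move the read-out far beyond it. Nothing available accounts for this step. On these data alone, a single step replaces both methyl groups and adds both methoxy groups, so the contribution of each remains open. Within the data shown here, also open is how a phenyl group carrying only one methoxy group, or a nitrile, would read on this nitrogen.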